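A few compounds are considered here, and "the series" means these few. Any claim that something is new, unique, unknown or untested is made for them only; others in the source may bear on it.

Measured compounds in a functional assay on CCRF-CEM cells (Homo sapiens) for cytotoxicity; on this read-out lower numbers stand for stronger inhibition and higher numbers for weaker inhibition:
- compound 1 `Cc1ccc(NC(=O)/C=C/C(=O)N2C/C(=C\c3ccc([N+](=O)[O-])cc3)C(=O)/C(=C/c3ccc([N+](=O)[O-])cc3)C2)cc1C`: 700 nM
- compound 2 `O=C(/C=C/C(=O)N1C/C(=C\c2ccc([N+](=O)[O-])cc2)C(=O)/C(=C/c2ccc([N+](=O)[O-])cc2)C1)Nc1ccc(Cl)c(Cl)c1`: 380 nM
- compound 3 `COc1ccc(NC(=O)/C=C/C(=O)N2C/C(=C\c3ccc([N+](=O)[O-])cc3)C(=O)/C(=C/c3ccc([N+](=O)[O-])cc3)C2)cc1`: 760 nM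

Compound 3 carries the largest number of the three, yet a 1.1-fold higher number from compound 1 to compound 3 (0.04 log units; within the scatter) and a 2.0-fold higher number from compound 2 to compound 3 (0.30 log units; within the scatter) both fall within the scatter, as does a 1.8-fold lower number from compound 1 to compound 2 (0.27 log units; within the scatter); the three variations of the aryl group on the amide nitrogen have not separated the compounds.

Compound 4 `O=C(/C=C/C(=O)N1C/C(=C\c2ccc([N+](=O)[O-])cc2)C(=O)/C(=C/c2ccc([N+](=O)[O-])cc2)C1)Nc1ccccc1` differs from compound 3 by hydrogen in place of methoxy on an aromatic carbon, i.e. 4-methoxyphenyl to phenyl. For the measured compounds named here, no measured step removes a methoxy, so the bearing of the earlier steps is indirect: each exchange of the aryl group so far stayed within the scatter. For a 1.1-fold lower number from compound 3 to compound 4 (0.04 log units; within the scatter) the expectation is therefore no step beyond the scatter, in either direction. Compound 4 is estimated at 700 nM, with a range of 350 nM to 1400 nM.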

Compound 4, half-maximal inhibitory concentration: 370 nM
For compound 4 the middle estimate is 1.9-fold (0.28 log units) above the measured one; the measured number falls inside the stated range.
By their numbers in this assay, from the lowest: compounds 4, 2, 1 and 3 (each within the scatter of the next, the first and the last beyond it).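

In this assay, for the compounds shown here, exchanging methoxy for hydrogen on this aromatic carbon gives the first step in the aryl series to lie beyond the scatter (a 2.1-fold lower number from compound 3 to compound 4 (0.31 log units; beyond the scatter)), though a modest one. Phenyl itself does not separate from the substituted aryl groups, since both remaining steps stay within the scatter (a 1.0-fold lower number from compound 2 to compound 4 (0.01 log units; within the scatter); a 1.9-fold lower number from compound 1 to compound 4 (0.28 log units; within the scatter)). No measured evidence on the series accounts for the methoxy step. Open, as far as these compounds go, is whether ethoxy, an amine or a carboxylic acid in place of methoxy would move the number further. Also open, from the compounds shown here alone, is whether the same exchange holds on another core.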